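A few compounds are considered here, and "the series" means these few. Any claim that something is new, unique, unknown or untested is made for them only; others in the source may bear on it.

Measured compounds in this series:
compound 1 `CCCCOC(=O)CCC(=O)N1CCN(CCCOc2cc3c(Nc4ccc(F)c(Cl)c4)ncnc3cc2OC)CC1` — 36.9%
compound 2 `CCCCCCCOC(=O)CCC(=O)N1CCN(CCCOc2cc3c(Nc4ccc(F)c(Cl)c4)ncnc3cc2OC)CC1` — 27.2%
compound 3 `CCCCCCCCCCCCCOC(=O)CCC(=O)N1CCN(CCCOc2cc3c(Nc4ccc(F)c(Cl)c4)ncnc3cc2OC)CC1` — 6.8%

In a functional assay on A549 cells (Homo sapiens) for cytotoxicity, read by MTT assay, with a stated time of 24 h, tested at 80 uM (on this read-out higher numbers stand for a weaker effect at the one concentration tested and lower numbers for a stronger effect), compound 3 stands lowest of the three measured numbers. The chain extensions seen so far read a number 9.7 percentage points lower from compound 1 to compound 2 (within the scatter), a number 30.1 percentage points lower from compound 1 to compound 3 (beyond the scatter) and a number 20.4 percentage points lower from compound 2 to compound 3 (beyond the scatter), so the two longer extensions moved the read-out down beyond the scatter. Compound 4 `CCCCCCCCCCCCCCCCOC(=O)CCC(=O)N1CCN(CCCOc2cc3c(Nc4ccc(F)c(Cl)c4)ncnc3cc2OC)CC1` carries the next extension of the same kind: propyl in place of hydrogen on a saturated chain carbon, ten or more bonds along the chain from an oxygen next to a carbonyl group. The steps from compound 1 and compound 2 to compound 3 bear directly on it and point downward, but compound 3 already sits close to the bottom of the scale, so any further change is expected to be small, at most a number 2.8 percentage points lower from compound 3 to compound 4 (within the scatter). Compound 4 is therefore estimated at 4%, with a range from 0% to 15%.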

Compound 4, a percentage reported as activity, at one concentration (the size of the read-out at that concentration, not a potency): 74.3%
The estimate for compound 4 lay 70.3 percentage points below the measured number; the measured number lies above the stated range.
By their numbers in this assay, from the lowest: compound 3; then compounds 2 and 1 (each within the scatter of the next); then compound 4.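

The read-out turns upward at the longest chain, with a number 67.5 percentage points higher from compound 3 to compound 4 (beyond the scatter), a number 47.1 percentage points higher from compound 2 to compound 4 (beyond the scatter) and a number 37.4 percentage points higher from compound 1 to compound 4 (beyond the scatter), so lengthening the chain does not lower the number throughout the series. Adding propyl to the chain has no single effect that carries across chain lengths: the same change on two cores in this assay, a number 9.7 percentage points lower (within the scatter) from compound 1 to compound 2 and a number 67.5 percentage points higher (beyond the scatter) from compound 3 to compound 4, 77.2 percentage points apart, beyond the scatter of two such steps. Adding nonyl behaves the same way: the same change on two cores in this assay, a number 30.1 percentage points lower (beyond the scatter) from compound 1 to compound 3 and a number 47.1 percentage points higher (beyond the scatter) from compound 2 to compound 4, 77.2 percentage points apart, beyond the scatter of two such steps.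

Going by these compounds, whether the turn is abrupt or gradual remains open, since the series shows no chain of intermediate length there. Also open, on these data alone, is how a longer chain, or a carboxylic acid in place of the ester, would read.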